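Dropping the 3-Aminopropyl Chain: Compound 3 to Compound 4

A few compounds are considered here, and "the series" means these few. Any claim that something is new, unique, unknown or untested is made for them only; others in the source may bear on it.

Measured compounds:
compound 1, `O=C(O)[C@@H]1CCCN1C(=O)CN(c1nc(Cl)nc2[nH]cnc12)C1CC1`: 23.6%
compound 2, `C[C@@H](O)[C@H](NC(=O)CN(c1nc(Cl)nc2[nH]cnc12)C1CC1)C(=O)O`: 37.6%
compound 3, `NCCCC[C@H](NC(=O)CN(c1nc(Cl)nc2[nH]cnc12)C1CC1)C(=O)OCc1ccccc1`: 16.8%

All three were tested in a functional assay on the whole organism (Tail, strain ICR) with Mus musculus as the target, in the tail flick test, with a stated time of 120 min, at a dose of 25 umol/kg by the oral route; a higher number here means a stronger effect of the compound at the dose given, a lower number a weaker effect. Compound 3 holds the lowest of the three numbers; its gap to compound 1 lies within the scatter, its gap to compound 2 beyond it. Compound 4, `C[C@H](NC(=O)CN(c1nc(Cl)nc2[nH]cnc12)C1CC1)C(=O)OCc1ccccc1`, is derived from compound 3 by the change (hydrogen in place of 3-aminopropyl on a saturated chain carbon, two bonds along the chain from an amide-type nitrogen and a carbonyl carbon). Among the compounds with values here, the only measured step, a number 14 percentage points higher from compound 1 to compound 2 (beyond the scatter), alters a different part of the molecule and bears on this change only loosely; it shows that changes on the group attached to the carbonyl carbon can shift the number modestly. Within the data shown here, no measured pair removes a 3-aminopropyl group. A small step is therefore expected for compound 4: a number 3.2 percentage points higher from compound 3 to compound 4 (within the scatter). In this assay compound 4 is estimated at 20%, ranging from 5% to 38%.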

Compound 4, a percentage reported as activity, at one dose (the size of the read-out at that dose, not a potency): 36.1%
Compound 4: middle estimate off by 16.1 percentage points, on the low side; the measured number falls inside the stated range.
By their numbers in this assay, from the lowest: compounds 3 and 1 (each within the scatter of the next); then compounds 4 and 2 (each within the scatter of the next).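

In this assay, the saturated chain carbon two bonds along the chain from an amide-type nitrogen and a carbonyl carbon proves to be a place where the read-out can move. Hydrogen in place of 3-aminopropyl gives a number 19.3 percentage points higher from compound 3 to compound 4 (beyond the scatter), so removing this chain, which ends in an amine, does not lower the read-out at this dose.

The shown compounds do not separate the amine from the chain that carries it, a question that a plain butyl chain in place of 4-aminobutyl could address. No measurement at hand explains the step.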